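This account rests on a few compounds, and the source may have more. Where it says the series, first, only, none or still open, it means among the compounds named here.

Compound 1 `C=C1C2=C(C(=O)N1OC)[C@H](OC(=O)CSc1nc3ccccc3o1)[C@@](C)(O)[C@H](CCCCC)O2`: 20000 nM
Compound 2 `C=C1C2=C(C(=O)N1OC)[C@H](OC(=O)CSc1nc3ccccc3s1)[C@@](C)(O)[C@H](CCCCC)O2`: 5900 nM

Both values come from a functional assay on A549 cells (Homo sapiens) for cytotoxicity, read by MTT assay, with a stated time of 72 h (on this read-out lower numbers stand for stronger inhibition and higher numbers for weaker inhibition), where compound 2 has the lower number of the two measured compounds. Compound 3 `C=C1C2=C(C(=O)N1OC)[C@H](OC(=O)CCCCCl)[C@@](C)(O)[C@H](CCCCC)O2` differs from compound 2 by 3-chloropropyl in place of (1,3-benzothiazol-2-yl)sulfanyl on a saturated chain carbon bound to a carbonyl carbon. In words, 3-chloropropyl stands in place of (1,3-benzothiazol-2-yl)sulfanyl on a saturated chain carbon bound to a carbonyl carbon.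

Within the data shown here, only one measured step bears on this, and only indirectly. Exchanging 1,3-benzoxazol-2-yl for 1,3-benzothiazol-2-yl on a sulfur gave a 3.4-fold lower number from compound 1 to compound 2 (0.53 log units; beyond the scatter), a modest step beyond the scatter. Among the measured compounds shown here, no measured compound lacks the aromatic group, so the size of the new step is poorly fixed. A modest step to a higher number is expected in this assay, with wide uncertainty. The expected change is a 2.0-fold higher number from compound 2 to compound 3 (0.31 log units; beyond the scatter). For compound 3 the estimate is 12000 nM, with an expected range of 3500 nM to 40000 nM.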

Compound 3, half-maximal inhibitory concentration: 12000 nM
Compound 3: the middle estimate sits on the measured number at the digits printed, within the range that was stated.
By their numbers in this assay, from the lowest: compound 2; then compounds 3 and 1 (each within the scatter of the next).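

In this assay the ring-free 3-chloropropyl group, on a saturated chain carbon bound to a carbonyl carbon, still leaves a measurable number, and the exchange for (1,3-benzothiazol-2-yl)sulfanyl is a modest step beyond the scatter (a 2.0-fold higher number from compound 2 to compound 3 (0.31 log units; beyond the scatter)). Against (1,3-benzoxazol-2-yl)sulfanyl the same group gives a step within the scatter (a 1.7-fold lower number from compound 1 to compound 3 (0.22 log units; within the scatter)), so in these compounds an aromatic group at this place does not by itself set the number apart, and only the 1,3-benzothiazol-2-yl compound stands apart from the 3-chloropropyl compound. Nothing available explains either step.

On these data alone, whether an amine, a carboxylic acid or a longer chain at this place would shift the number remains open. So does the part played by the chlorine, for which a plain propyl group would be the direct comparison.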